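A few compounds are considered here, and "the series" means these few. Any claim that something is new, unique, unknown or untested is made for them only; others in the source may bear on it.

Within the data shown here, compound 1 `COc1cc2c(cc1OC)C(CC(=O)N(C)C)CC2` stands highest of the three numbers measured so far in a functional assay on the whole organism (strain Wistar) for inhibition, with Rattus norvegicus as the target, read by paw edema, with stated times of 60 min and 6 h, at a dose of 100 mg/kg by the oral route (a lower number here means less inhibition, a higher number more inhibition at the dose given (going by the name of the read-out)), where compound 1 gives 33.3%. Compound 2 `CCNC(=O)CC1CCc2cc(OC)c(OC)cc21` gives 20.4%, and compound 3 `CCCCNC(=O)CC1CCc2cc(OC)c(OC)cc21` gives 24.1%. Both measured steps from compound 1 alter the group on the carbonyl carbon: a number 12.9 percentage points lower from compound 1 to compound 2 (beyond the scatter), while a number 9.2 percentage points lower from compound 1 to compound 3 (within the scatter). The step of a number 3.7 percentage points higher from compound 2 to compound 3 (within the scatter) stays within the scatter. Compound 4 `COc1cc2c(cc1OC)C(CC(=O)N1CCOCC1)CC2` changes the same place on the shared core: morpholin-4-yl in place of dimethylamino on a carbonyl carbon. The two steps that bear on this change point downward, one beyond the scatter and one within it, so a modest fall rather than a rise is expected: a number 8.3 percentage points lower from compound 1 to compound 4 (within the scatter). Compound 4 is estimated at 25%, with a range from 12% to 38%.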

Compound 4, a percentage reported as inhibition, in the whole organism at one dose (the size of the read-out at that dose, not a potency): 14.8%
The estimate for compound 4 lay 10.2 percentage points above the measured number; measured number inside the range.
By their numbers in this assay, from the lowest: compounds 4, 2, 3 and 1 (each within the scatter of the next, the first and the last beyond it).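

In this assay, among these compounds, morpholin-4-yl, the first group on this carbonyl carbon to bring a ring, falls clearly short of dimethylamino (a number 18.5 percentage points lower from compound 1 to compound 4 (beyond the scatter)). Against the other two amides the steps stay within the scatter (a number 9.3 percentage points lower from compound 3 to compound 4 (within the scatter); a number 5.6 percentage points lower from compound 2 to compound 4 (within the scatter)), so morpholin-4-yl cannot be ranked apart from butylamino or ethylamino. No measurement here explains the fall from dimethylamino. From the compounds shown here alone, what remains open is whether the ring itself or its oxygen goes with the lower number; piperidin-1-yl, the same ring with carbon in place of that oxygen, would bear on this.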